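Oral exposure in the series: from compound 2 to compound 3

The compounds below may be only part of what the source reports. "The series", "measured", "known", "first", "only" and "open" are said of these compounds alone.

Going by the values given here, compound 2 `Cc1nc(C)n(CC(=O)N2CCN(c3sc(C(F)(F)F)nc3-c3nc4ccc(C5CCOCC5)cc4[nH]3)C[C@H]2C)n1` gives 3360 nM in an ADME assay on the whole organism (Mus musculus, strain Balb/c) for pharmacokinetics, at a dose of 10 mg/kg by the oral route (on this read-out lower numbers stand for lower exposure and higher numbers for higher exposure at the dose given), the higher of the two numbers known so far; compound 1 `C[C@@H]1CN(c2sc(C(F)(F)F)nc2-c2nc3ccccc3[nH]2)CCN1C(=O)Cn1cccn1` gives 1410 nM in this assay, a gap beyond the scatter. Compound 3 `Cc1nc(C)n(CC(=O)N2CCN(c3sc(C(F)(F)F)nc3-c3nc4ccc(C5CCN(C)CC5)cc4[nH]3)C[C@H]2C)n1` differs from compound 2 by 1-methylpiperidin-4-yl in place of oxan-4-yl on an aromatic carbon. Among the compounds with values here, no step of this kind between measured compounds is available to lean on. A modest downward step in this assay is expected, not far from the scatter, which amounts to an estimated 1.7-fold lower number from compound 2 to compound 3 (0.23 log units; within the scatter). Compound 3 is expected to reach 2000 nM, with a likely range from 600 nM to 6000 nM.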

Compound 3, maximal plasma concentration: 50.7 nM
Compound 3: middle estimate off by 39-fold (1.60 log units), on the high side, and the stated range ends above it.
By their numbers in this assay, from the lowest: compound 3; then compound 1; then compound 2.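

Exposure in this assay depends strongly on the group at this aromatic carbon: 1-methylpiperidin-4-yl in place of oxan-4-yl gives a 66-fold lower number from compound 2 to compound 3 (1.82 log units; beyond the scatter) and drops compound 3 below compound 1. The two rings are both six-membered and non-aromatic, with one hetero atom each, so this count does not separate them. Nothing available accounts for the drop.

Still open, from the compounds shown here alone, is whether an unsubstituted piperidin-4-yl or an N-acetylpiperidin-4-yl would keep the loss. Going by these compounds, it is also open whether the same change behaves alike on the core of compound 1.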